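A dimethylaminobutyl chain added to compound 1

The source may report more compounds than this note shows. Statements on the series, on what has been measured and on what is new or still open speak of the compounds shown alone.

Measured in a functional assay on Raji cells (Homo sapiens) for antiproliferative activity, read by MTT assay, with a stated time of 48 h; on this read-out higher numbers stand for weaker inhibition and lower numbers for stronger inhibition:
compound 1 `Cn1c(N)c(-c2nc3ccccc3[nH]2)c2nc(C#N)c(C#N)nc21`: > 50000 nM, a limit
compound 2 `CCN(CC)CCCn1c(N)c(-c2nc3ccccc3[nH]2)c2nc(C#N)c(C#N)nc21`: 1870 nM
compound 3 `CCCCn1c(N)c(-c2nc3ccccc3[nH]2)c2nc(C#N)c(C#N)nc21`: > 50000 nM, a limit

Compound 1 stands at > 50000 nM, which is a limit of the assay and not a number. Compound 4 `CN(C)CCCCn1c(-c2c(N)n(C)c3nc(C#N)c(C#N)nc23)nc2ccccc21` has not yet been measured. It differs from compound 1 by one change: 4-(dimethylamino)butyl in place of hydrogen on an aromatic nitrogen.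

Among the measured compounds shown here, three measured steps bear on this change. Adding a chain that ends in diethylamino gave an at least 26-fold lower number from compound 1 to compound 2 (1.42 log units; beyond the scatter). Adding a plain propyl gave a step that the two limits leave unreadable from compound 1 to compound 3. Putting methyl in place of diethylamino gave an at least 26-fold higher number from compound 2 to compound 3 (1.42 log units; beyond the scatter). Among these three compounds, then, only compound 2, the one with an amino group at the chain end, gives a readable number.

Compound 4 also carries such a chain, but the place differs. The measured steps sit on a saturated chain carbon bound to an aromatic nitrogen, while the new chain sits on an aromatic nitrogen of a five-membered aromatic ring with 2 nitrogen. A large step towards stronger inhibition is therefore expected, though with wide uncertainty, and it is estimated as an at least 10-fold lower number from compound 1 to compound 4 (1.00 log units; beyond the scatter). For compound 4 the estimate is 5000 nM, with an expected range from 1200 nM to 30000 nM.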

Compound 4, half-maximal inhibitory concentration: 1070 nM
For compound 4 the middle estimate is 4.7-fold (0.67 log units) above the measured one; measured number outside the range, below it.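

In this assay, the core of compound 1 also responds to a chain on a second site: 4-(dimethylamino)butyl in place of hydrogen on an aromatic nitrogen of the five-membered aromatic ring gives an at least 46-fold lower number from compound 1 to compound 4 (1.66 log units; beyond the scatter). The earlier readable step, an at least 26-fold lower number from compound 1 to compound 2 (1.42 log units; beyond the scatter), came from a chain built on the methyl group of compound 1, whereas compound 4 keeps that methyl, so among the compounds shown a gain is no longer tied to that one site; compound 2 and compound 4 both carry a chain ending in an amino group, while compound 3, with its plain butyl chain, gives no readable step from compound 1. Compound 1 stands at > 50000 nM, which is a limit and not a number, so the true size of the new step stays unknown: the limit of > 50000 nM in this assay, at which 2 of the 4 values shown sit.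

A plain butyl chain on this same aromatic nitrogen would show whether the amino group at the chain end is needed at this site, as it appears to be on the other chain. A shorter chain ending in dimethylamino, or a chain ending in a carboxylic acid, would show how much the length of the chain and the kind of end group matter here.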